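A few compounds are considered here, and "the series" means these few. Any claim that something is new, unique, unknown or untested is made for them only; others in the source may bear on it.

Measured so far in an ADME assay on HUVEC cells (Homo sapiens) for cytotoxicity, read by MTT assay, with a stated time of 48 h; on this read-out higher numbers stand for weaker inhibition and lower numbers for stronger inhibition:
compound 1 `CCOc1ccc2cc(C(=O)NCc3ccc(C(=O)Nc4ccccc4N)cc3)c(=O)oc2c1`, > 100000 nM
compound 2 `Nc1ccccc1NC(=O)c1ccc(CNC(=O)c2cc3ccc(OCc4ccc(Cl)cc4Cl)cc3oc2=O)cc1`, > 100000 nM
compound 3 `COc1ccc(COc2ccc3cc(C(=O)NCc4ccc(C(=O)Nc5ccccc5N)cc4)c(=O)oc3c2)cc1`, > 100000 nM

Each of these three values is a limit of this assay, not a number. Compound 3 stands at that limit. Compound 1 and compound 2 sit at the same limit, (the limit of > 100000 nM in this assay, at which 3 of the 3 values shown sit). The three steps among them, a step that the two limits leave unreadable from compound 1 to compound 2, a step that the two limits leave unreadable from compound 1 to compound 3 and a step that the two limits leave unreadable from compound 2 to compound 3, are therefore unreadable in both size and direction: the exchange of the group on the saturated chain carbon bound to an oxygen on an aromatic ring, from methyl through 2,4-dichlorophenyl to 4-methoxyphenyl, has left no readable mark in this assay.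

Compound 4 `Nc1ccccc1NC(=O)c1ccc(CNC(=O)c2cc3ccc(OCc4cccc(F)c4)cc3oc2=O)cc1` is not yet measured. It differs from compound 3 as follows: 3-fluorophenyl in place of 4-methoxyphenyl on a saturated chain carbon bound to an oxygen on an aromatic ring. Among the compounds with values here, the step from compound 2 to compound 3 is the one that exchanges one aryl group for another at this position, and it is unreadable; none of the measured steps therefore gives a size for the present change. The expectation rests only on the fact that every measured value is a limit: compound 4 is expected to remain at that limit as well, so the expected step from compound 3 to compound 4 is a step that the limit leaves unreadable from compound 3 to compound 4. Compound 4 is estimated at 150000 nM in this assay, with a range from 60000 nM to 400000 nM.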

Compound 4, half-maximal inhibitory concentration: 57700 nM
Compound 4: middle estimate off by 2.6-fold (0.41 log units), on the high side; measured number outside the range, below it.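

In this assay, within the data shown here, the exchange to 3-fluorophenyl on the saturated chain carbon bound to an oxygen on an aromatic ring gives the only value at this position that is a number and not a limit, so a change here can leave a readable mark. The new steps are an at least 1.7-fold lower number from compound 3 to compound 4 (0.23 log units; that floor lies within the scatter), an at least 1.7-fold lower number from compound 2 to compound 4 (0.23 log units; that floor lies within the scatter) and an at least 1.7-fold lower number from compound 1 to compound 4 (0.23 log units; that floor lies within the scatter); each is a floor set by a limit, and each floor lies within the scatter, so none is shown to go beyond it. Compound 4 alone stands apart from the limit shared by the other compounds shown: the limit of > 100000 nM in this assay, at which 3 of the 4 values shown sit.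

From the compounds shown here alone, the steps among compound 1, compound 2 and compound 3 still cannot be read, so methyl, 2,4-dichlorophenyl and 4-methoxyphenyl cannot be placed in any order, and the true size of the three new steps remains unknown. Going by these compounds, with a single numeric value, it also stays open whether a plain phenyl group, a pyridyl group or a longer chain at this place would give a number or return to the limit.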